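This account rests on a few compounds, and the source may have more. Where it says the series, first, only, none or still open, it means among the compounds named here.

Notes on the series: in a physicochemical assay for solubility, read by LC-MS, using the shake flask method, measured as thermodynamic solubility, with a stated time of 24 h, at pH 6.5 (a higher number here means a more soluble compound, a lower number a less soluble compound), compound 3 (`O=[N+]([O-])c1ccc(-n2cc(CCO[C@H]3O[C@H](CO)[C@@H](O)[C@H](O)[C@@H]3O)nn2)cc1`) gives > 3000 ug/mL, which is a limit and not a number. This is the limit of > 3000 ug/mL in this assay, at which 2 of the 3 values shown sit. Compound 2 (`OC[C@H]1O[C@H](OCc2cn(-c3cccc(F)c3)nn2)[C@@H](O)[C@@H](O)[C@@H]1O`) gives > 3000 ug/mL, also a limit. Compound 1 (`Nc1ccc(-n2cc(CO[C@H]3O[C@H](CO)[C@@H](O)[C@H](O)[C@@H]3O)nn2)cc1`) gives > 2000 ug/mL, again a limit.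

Compound 4 (`OC[C@H]1O[C@H](OCCc2cn(-c3ccncc3)nn2)[C@@H](O)[C@@H](O)[C@@H]1O`) differs from compound 3 as follows: pyridin-4-yl in place of 4-nitrophenyl on an aromatic nitrogen. In words, pyridin-4-yl stands in place of 4-nitrophenyl on an aromatic nitrogen. Within the data shown here, the one measured step that changes the group on this nitrogen is a step that the two limits leave unreadable from compound 1 to compound 2, so it offers no size to carry over. No step beyond the scatter is expected in this assay, and the estimated step is a step that the limit leaves unreadable from compound 3 to compound 4. For compound 4 the estimate is 3500 ug/mL, with an expected range of 2000 ug/mL to 8000 ug/mL.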

Compound 4, solubility: > 3000 ug/mL
Compound 4 ended at the assay's limit; the forecaster's own chance of this, stated with the estimate: 85%; the middle value lies beyond the limit too.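

In this assay, no step can be read between compound 3 and compound 4, as both values are limits and not numbers: the limit of > 3000 ug/mL in this assay, at which 3 of the 4 values shown sit.

The compounds shown leave open how far any of them lies past its limit, and so what changing the group on the aromatic nitrogen does to solubility.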